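The source may hold more compounds than are shown below. What is called first, only, known or untested is meant among the compounds shown, and "the series" means these compounds.

Compound 1 `COc1cc(-c2nc(N(C)C)sc2-c2ccc3ccccc3c2)cc(OC)c1OC`: 2390 nM
Compound 2 `COc1ccc(-c2sc(N(C)C)nc2-c2cc(OC)c(OC)c(OC)c2)cc1`: 8360 nM

Both compounds were tested in a functional assay on MCF7 cells (Homo sapiens) for antiproliferative activity, read by MTT assay, with a stated time of 72 h; on this read-out higher numbers stand for weaker inhibition and lower numbers for stronger inhibition. Of the two numbers, compound 2 has the higher, 8360 nM, so it is the weaker inhibitor. Among the measured compounds shown here, its only neighbour is compound 1, at 2390 nM.

Compound 3 `CCOc1ccc(-c2sc(N(C)C)nc2-c2cc(OC)c(OC)c(OC)c2)cc1` differs from compound 2 in one place: methyl in place of hydrogen on a saturated chain carbon bound to an oxygen on an aromatic ring. This is methyl in place of hydrogen on a saturated chain carbon bound to an oxygen on an aromatic ring, which turns 4-methoxyphenyl into 4-ethoxyphenyl.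

For the measured compounds named here, only one measured step involves this group: a 3.5-fold higher number from compound 1 to compound 2 (0.54 log units; beyond the scatter). That modest step swaps a whole group, 4-methoxyphenyl in place of naphthalen-2-yl, so it is only a loose guide. Going by the values given here, no measured compound shows what lengthening the chain on the oxygen does. The change here is much smaller, so no shift beyond the scatter is expected. Any drift should lean slightly lower, a weak guess resting on compound 1 at 2390 nM.

The expected result is a 1.5-fold lower number from compound 2 to compound 3 (0.18 log units; within the scatter). For compound 3 the estimated value is 5500 nM, with an expected range of 2000 nM to 15000 nM.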

Compound 3, half-maximal inhibitory concentration: > 10000 nM
Compound 3: no number, only a limit (the forecaster's own chance of this, stated with the estimate: 10%); at least 1.8-fold (0.25 log units) between middle value and limit.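

Compound 3 gives no number in this assay, only a limit of the assay: the limit of > 10000 nM in this assay, at which 1 of the 3 values shown sits. From the compounds shown here alone, putting methyl in place of hydrogen on the saturated chain carbon bound to the oxygen, which turns methoxy into ethoxy, gives an at least 1.1-fold higher number from compound 2 to compound 3 (0.07 log units; that floor lies within the scatter), so this small change does not bring the number down towards that of the naphthalen-2-yl compound, although the true size of the step stays unknown and could be small or large. Against the naphthalen-2-yl group, 4-ethoxyphenyl gives an at least 4.1-fold higher number from compound 1 to compound 3 (0.62 log units; beyond the scatter), and since 4-methoxyphenyl also lies beyond the scatter from it, compound 1 is the strongest inhibitor of the three, with neither of these two 4-alkoxyphenyl groups matching naphthalen-2-yl on this aromatic carbon.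

The compounds shown leave open how far the number would climb with a longer chain on the oxygen, such as propoxy or butoxy, since the limit hides where ethoxy itself lies. They also leave open how a hydroxy group or an amine would read at the same place on the phenyl ring, and whether any other fused aromatic group would do as well as naphthalen-2-yl.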